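A small change at an amide-type nitrogen

A few compounds are considered here, and "the series" means these few. Any claim that something is new, unique, unknown or untested is made for them only; others in the source may bear on it.

Measured so far in a functional assay on MCF7 cells (Homo sapiens) for antiproliferative activity, read by MTT assay, with a stated time of 24 h; on this read-out lower numbers stand for stronger inhibition and higher numbers for weaker inhibition
- Compound 1 (`CCn1c(C(=O)N[C@@H](C)C(=O)OC)ccc1C(CC)(CC)c1ccc(OCS(=O)(=O)c2ccccc2)c(C)c1`) gives 43700 nM
- Compound 2 (`CCn1c(C(=O)N[C@H](C)CO)ccc1C(CC)(CC)c1ccc(OCS(=O)(=O)c2ccccc2)c(C)c1`) gives 10600 nM

Compound 2 holds the lower of these two numbers, so it is the stronger inhibitor of the pair. Compound 3 (`CCn1c(C(=O)NC(C)(C)CO)ccc1C(CC)(CC)c1ccc(OCS(=O)(=O)c2ccccc2)c(C)c1`) differs from it in one place (1-(hydroxymethyl)-1-methylethyl in place of 1-(hydroxymethyl)ethyl on an amide-type nitrogen), with 1-(hydroxymethyl)-1-methylethyl in place of 1-(hydroxymethyl)ethyl on an amide-type nitrogen. Going by the values given here, the only measured step at such a nitrogen is modest but beyond the usual scatter (a 4.1-fold lower number from compound 1 to compound 2 (0.62 log units; beyond the scatter)). That step replaced 1-(methoxycarbonyl)ethyl, a group that is absent from both compound 2 and compound 3, so it offers little guidance here. No step beyond the scatter is therefore expected in this assay and no direction is favoured, which leaves the expected step small (a 1.1-fold lower number from compound 2 to compound 3 (0.03 log units; within the scatter)). Compound 3 is estimated at 10000 nM with 4000 nM and 28000 nM as the expected ends of its range.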

Compound 3, half-maximal inhibitory concentration: 20700 nM
For compound 3 the middle estimate is 2.1-fold (0.32 log units) below the measured one; measured number inside the range.
By their numbers in this assay, from the lowest: compounds 2 and 3 (each within the scatter of the next); then compound 1.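

In this assay, going from 1-(hydroxymethyl)ethyl to 1-(hydroxymethyl)-1-methylethyl on the amide-type nitrogen, which also removes the defined stereocentre, leaves the two numbers indistinguishable (a 2.0-fold higher number from compound 2 to compound 3 (0.29 log units; within the scatter)), so this position accepts the larger group without a change that can be read. Compound 3 also stands apart from compound 1 (a 2.1-fold lower number from compound 1 to compound 3 (0.32 log units; beyond the scatter)), so both hydroxymethyl-bearing groups shown now give lower numbers than 1-(methoxycarbonyl)ethyl, and none of the three compounds goes against this. Nothing on hand explains this difference between the groups.

The compounds shown leave open how a carboxylic acid or an amine at this nitrogen would read, and whether a longer chain ending in a hydroxyl would stay at the same level. They also leave open how the opposite stereocentre of compound 2 would compare.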